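Removing a Methyl from a Fused Core: Expecting Compound 4

This account rests on a few compounds, and the source may have more. Where it says the series, first, only, none or still open, it means among the compounds named here.

In a functional assay on MCF7 cells (Homo sapiens) for inhibition, read by MTT assay, with a stated time of 48 h (on this read-out higher numbers stand for weaker inhibition and lower numbers for stronger inhibition), compound 1 `CC(=O)c1ccc(NC(=O)CSc2nc3c([nH]2)c(=O)n(C)c(=O)n3C)cc1` gives 6100 nM. Compound 2 `CC(=O)c1ccc(NC(=O)CSc2nc3[nH]c(=O)n(C)c(=O)c3[nH]2)cc1` differs from it by a single change, (hydrogen in place of methyl on an aromatic nitrogen), and in this assay compound 2 gives 6100 nM. The step of no change at the digits printed from compound 1 to compound 2 (within the scatter) shows that this change left the read-out essentially where it was. Compound 3 `Cn1c(=O)c2[nH]c(SC/C(=N/O)c3ccccc3)nc2n(C)c1=O` carries a different side chain on a core of the same kind; the difference between the two cores is not broken down here. In this assay compound 3 gives 5900 nM, a number lying within the scatter of compound 1 and compound 2. Among the compounds with values here, compound 4 `Cn1c(=O)[nH]c2nc(SC/C(=N/O)c3ccccc3)[nH]c2c1=O` is the unmeasured partner of compound 3, related to it by hydrogen in place of methyl on an aromatic nitrogen, which is the same change, at a place described in exactly the same way, as the one that turned compound 1 into compound 2. Because no change at the digits printed from compound 1 to compound 2 (within the scatter) was flat, the step expected for compound 4 is a 1.0-fold higher number from compound 3 to compound 4 (0.01 log units; within the scatter). The estimate for compound 4 in this assay is therefore 6000 nM, expected to fall between 3000 nM and 12000 nM.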

Compound 4, half-maximal inhibitory concentration: 4300 nM
Compound 4: middle estimate off by 1.4-fold (0.14 log units), on the high side; the range from low to high includes it.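

In this assay, putting hydrogen in place of methyl on an aromatic nitrogen gives a 1.4-fold lower number from compound 3 to compound 4 (0.14 log units; within the scatter), so on this second core the change again stays within the scatter. Set beside the earlier step, the change looks the same on both cores: the same change on two cores in this assay, no change at the digits printed (within the scatter) from compound 1 to compound 2 and a 1.4-fold lower number (0.14 log units; within the scatter) from compound 3 to compound 4, 1.4-fold (0.14 log units) apart, within the scatter of two such steps

Within the data shown here, for these two pairs, then, the flat result carries over from one core and side chain to the other, but that is only two pairs in one cell assay, and neither step is large enough to reveal a real difference between the cores, nor does it show that the same would hold on any other core or in any other test.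

The compounds shown leave open what happens when this nitrogen carries something other than hydrogen or methyl, such as an ethyl group or a longer chain. They also leave open whether a side chain bearing an amine or a carboxylic acid would respond to the loss of the methyl in the same way.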